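Compound 3 to compound 4: the aromatic nitrogen group

The source may report more compounds than this note shows. Statements on the series, on what has been measured and on what is new or still open speak of the compounds shown alone.

In a physicochemical assay for lipophilicity (on this read-out higher numbers stand for higher lipophilicity and lower numbers for lower lipophilicity), compound 3 (`CNC(=O)c1cc(C(=O)N[C@H]2[C@@H]3C[C@H](O)C[C@@H]32)n([C@@H](C)c2cccc(Cl)c2)n1`) gives 3.7. Among the measured compounds shown here, compound 1 (`CNC(=O)c1cc(C(=O)N[C@H]2CC[C@H](O)CC2)n([C@@H](C)c2cccc(Cl)c2)n1`) is level with it at 3.7, and the two share the highest number of the three measured so far. Compound 2 (`CNC(=O)c1cc(C(=O)N[C@H]2[C@@H]3C[C@@H](OC)C[C@@H]32)n([C@@H](C)c2ccccc2)n1`) is clearly lower at 2.7.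

The next structure is compound 4 (`CC[C@@H](c1ccccc1)n1nc(C(=O)NC)cc1C(=O)N[C@H]1[C@@H]2C[C@H](O)C[C@@H]21`), with 1-phenylpropyl in place of 1-(3-chlorophenyl)ethyl on an aromatic nitrogen.

For the measured compounds named here, no measured step covers this change directly. The only one available, no change at the digits printed from compound 1 to compound 3 (within the scatter), lies on an amide-type nitrogen, a different place in the molecule, so it offers little guidance beyond suggesting that compound 3 is a fair reference point. Going by the values given here, compound 2, at 2.7, is the only measured compound without the chlorine, but it also differs from compound 3 on the amide-type nitrogen group, so its gap cannot be assigned to a single change. It does point towards a lower number, although the longer chain in 1-phenylpropyl keeps the expected fall smaller than that gap.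

A modest fall in this assay is therefore expected, an estimated a number 0.40 log units lower from compound 3 to compound 4 (beyond the scatter). The estimate for compound 4 is 3.3, with an expected range of 2.8 to 3.8.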

Compound 4, distribution coefficient: 3.6
Compound 4: middle estimate off by 0.30 log units, on the low side; the range from low to high includes it.
By their numbers in this assay, from the lowest: compound 2; then compounds 4, 1 and 3 (each within the scatter of the next).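

In this assay, 1-phenylpropyl in place of 1-(3-chlorophenyl)ethyl on the aromatic nitrogen gives a number 0.10 log units lower from compound 3 to compound 4 (within the scatter). Among the compounds shown here, this is the first step at this position, the earlier step lying on an amide-type nitrogen, and it shows that removing the chlorine from the aromatic ring and changing the ethyl link to propyl can occur together while the read-out stays within the scatter, with the heavy-atom count of the group unchanged at 9. Nothing measured here offers an explanation for this result.

Going by these compounds, the effect of each part of the swap remains open: the chlorine and the propyl chain change together in this step, so a small net step could hide either two small contributions or two larger opposing ones. Also open, on these data alone, is whether the read-out would stay within the scatter with a different kind of group on this aromatic nitrogen, such as a longer chain like 1-phenylbutyl or a 1-phenylethyl group carrying an amine or a carboxylic acid on its aromatic ring.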